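Pentafluoroethyl for nitro, carried to a second core

The source may hold more compounds than are shown below. What is called first, only, known or untested is meant among the compounds shown, and "the series" means these compounds.

Measured in a functional assay (aorta) with Rattus norvegicus as the target; on this read-out higher numbers stand for an effect only at larger amounts of compound and lower numbers for an effect already at smaller amounts:
compound 1, `O=c1ccccn1[C@@H]1c2cc([N+](=O)[O-])ccc2OC(CF)(CF)[C@H]1O`: 28.8 nM
compound 2, `O=c1ccccn1[C@@H]1c2cc(C(F)(F)C(F)(F)F)ccc2OC(CF)(CF)[C@H]1O`: 12 nM
compound 3, `O=[N+]([O-])c1ccc2c(c1)C(c1cccc[n+]1[O-])=CC(CF)(CF)O2`: 1.74 nM

Compound 2 differs from compound 1 by 1,1,2,2,2-pentafluoroethyl in place of nitro on an aromatic carbon, and in this assay this gave a 2.4-fold lower number from compound 1 to compound 2 (0.38 log units; beyond the scatter). Compound 3 is built on a different core; how its core differs from that of compound 1 is not broken down here. In this assay compound 3 has the lowest number of the three, and its gaps to compound 2 and to compound 1 are both beyond the scatter.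

Compound 4, `[O-][n+]1ccccc1C1=CC(CF)(CF)Oc2ccc(C(F)(F)C(F)(F)F)cc21`, is not yet measured. It differs from compound 3 by 1,1,2,2,2-pentafluoroethyl in place of nitro on an aromatic carbon, the same change at the same place as that between compound 1 and compound 2. Going by the values given here, only this single earlier step is available to judge the change, since the two cores are not the same. A step of about the same size is expected, a 2.3-fold lower number from compound 3 to compound 4 (0.37 log units; beyond the scatter), resting on the earlier pair, which showed a 2.4-fold lower number from compound 1 to compound 2 (0.38 log units; beyond the scatter). Compound 4 is therefore estimated at 0.75 nM in this assay, most likely between 0.3 nM and 2 nM.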

Compound 4, half-maximal effective concentration: 1.7 nM
For compound 4 the middle estimate is 2.3-fold (0.36 log units) below the measured one; the measured number falls inside the stated range.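

Putting 1,1,2,2,2-pentafluoroethyl in place of nitro on the core of compound 3 gave, in this assay, a 1.0-fold lower number from compound 3 to compound 4 (0.01 log units; within the scatter), so on this core the two groups cannot be told apart. Set beside the step on the core of compound 1, this result does not separate from it: the same change on two cores in this assay, a 2.4-fold lower number (0.38 log units; beyond the scatter) from compound 1 to compound 2 and a 1.0-fold lower number (0.01 log units; within the scatter) from compound 3 to compound 4, 2.3-fold (0.37 log units) apart, within the scatter of two such steps The data therefore give no ground for claiming that the change acts differently on the two cores, but with a single pair on each core they do not show that it acts alike, and the step that lay beyond the scatter on the first core was not repeated as such on the second.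

The compounds shown carry only these two groups at this place, so it remains open how a trifluoromethyl group, a nitrile or a chlorine atom there would compare on either core. From the compounds shown here alone, whether the two steps would also agree in any read-out other than this assay stays open as well.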